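The source may hold more compounds than are shown below. What is called first, only, known or untested is meant among the compounds shown, and "the series" means these compounds.

Compound 1 `O=C(CC(CC(=O)NC1Cc2ccccc2C1)c1ccccc1)NCCN1CCCCC1` and compound 2 `O=C(CC(CC(=O)NC1Cc2ccccc2C1)c1ccccc1)NCCN1CCCC1` share one core and differ by pyrrolidin-1-yl in place of piperidin-1-yl on a saturated chain carbon, two bonds along the chain from an amide-type nitrogen. In a functional assay on MGC-803 cells (Homo sapiens) for inhibition (a lower number here means a stronger inhibitor, a higher number a weaker inhibitor), compound 1 reaches only a limit of the assay, > 100000 nM. Compound 2 likewise gives only a limit in this assay, > 100000 nM. The step that the two limits leave unreadable from compound 1 to compound 2 is thus unreadable, both compounds sitting at the limit of > 100000 nM in this assay, at which 2 of the 3 values shown sit. Compound 3 `CCN(C(=O)CC(CC(=O)NCCN1CCCCC1)c1ccc(Cl)cc1)C1Cc2ccccc2C1` carries a different core, and the difference between the two cores is not broken down here. In this assay, for the measured compounds named here, compound 3 gives 21200 nM, the only number among the three. Compound 4 `CCN(C(=O)CC(CC(=O)NCCN1CCCC1)c1ccc(Cl)cc1)C1Cc2ccccc2C1` differs from compound 3 by pyrrolidin-1-yl in place of piperidin-1-yl on a saturated chain carbon, two bonds along the chain from an amide-type nitrogen, the same change as between compound 1 and compound 2. With that earlier step unreadable, the step of a 1.2-fold higher number from compound 3 to compound 4 (0.07 log units; within the scatter) is expected to be small because compound 3 gives 21200 nM as the only anchor. Compound 4 is estimated at 25000 nM, expected to lie between 8000 nM and 80000 nM.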

Compound 4, half-maximal inhibitory concentration: 55500 nM
Beside the measured number, compound 4's estimate is 2.2-fold (0.35 log units) below it; measured number inside the range.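

In this assay, the change from piperidin-1-yl to pyrrolidin-1-yl can be read on one core only, as a 2.6-fold higher number from compound 3 to compound 4 (0.42 log units; beyond the scatter), a modest loss of inhibition. On the other core the same change cannot be read, with compound 1 and compound 2 each giving only a limit of the assay: the limit of > 100000 nM in this assay, at which 2 of the 4 values shown sit. The series therefore shows neither that the step carries over from one core to the other nor that it fails to, and a single readable pair sets no rule.

As far as these compounds go, how a morpholin-4-yl or azepan-1-yl group at the same place would compare with piperidin-1-yl in this assay remains open. Also open, from the compounds shown here alone, is whether the step keeps its size on any further core.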